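Chain Lengthening on a Shared Triazolopyrimidine-like Core

This account rests on a few compounds, and the source may have more. Where it says the series, first, only, none or still open, it means among the compounds named here.

Measured so far:
compound 1, `CCNc1nc(-c2ccccc2)nc2c1nnn2Cc1ccccc1F`: 11 nM
compound 2, `CCCCNc1nc(-c2ccccc2)nc2c1nnn2Cc1ccccc1`: 11 nM
compound 3, `CCCCNc1nc(-c2ccccc2)nc2c1nnn2Cc1ccccc1F`: 4.3 nM

All three were tested in an assay on Cerebral cortex for displacement of a labelled ligand from adenosine receptor A1 (Bos taurus); on this read-out lower numbers stand for stronger inhibition and higher numbers for weaker inhibition. In this assay compound 1 and compound 2 stand level at the digits shown, and compound 3 sits below both: a 2.6-fold lower number from compound 1 to compound 3 (0.41 log units; beyond the scatter) and a 2.6-fold lower number from compound 2 to compound 3 (0.41 log units; beyond the scatter) are both modest steps beyond the scatter. The change from compound 1 to compound 3 is ethyl in place of hydrogen on a saturated chain carbon, two bonds along the chain from a nitrogen on an aromatic ring. The difference between the core of compound 1 and the core of compound 2 is not broken down here.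

Compound 4, `CCCCCCNc1nc(-c2ccccc2)nc2c1nnn2Cc1ccccc1`, is not yet measured. It differs from compound 2 by ethyl in place of hydrogen on a saturated chain carbon, four bonds along the chain from a nitrogen on an aromatic ring, the same kind of change as from compound 1 to compound 3, but sitting four bonds along the chain from the nitrogen rather than two. Because a 2.6-fold lower number from compound 1 to compound 3 (0.41 log units; beyond the scatter) was modest, a step of about a 1.4-fold lower number from compound 2 to compound 4 (0.14 log units; within the scatter) is expected here, though the different place leaves this uncertain. Compound 4 is therefore estimated at 8 nM, between 3 nM and 25 nM.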

Compound 4, inhibition constant: 13.2 nM
Compound 4: middle estimate off by 1.7-fold (0.22 log units), on the low side; measured number inside the range.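

In this assay, placing ethyl in place of hydrogen on a saturated chain carbon, four bonds along the chain from a nitrogen on an aromatic ring, gives a 1.2-fold higher number from compound 2 to compound 4 (0.08 log units; within the scatter), so the two numbers cannot be told apart. Set beside the earlier step, the change does not carry over from one core to the other with the same size: the same change on two cores in this assay, a 2.6-fold lower number (0.41 log units; beyond the scatter) from compound 1 to compound 3 and a 1.2-fold higher number (0.08 log units; within the scatter) from compound 2 to compound 4, 3.1-fold (0.49 log units) apart, beyond the scatter of two such steps This is only one pair of steps, and the pairs differ in two ways: compound 1 and compound 3 carry a fluoro on an aromatic carbon that compound 2 and compound 4 lack, and the change sits two bonds along the chain in one pair and four in the other, so these results cannot show which difference matters.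

Still open, as far as these compounds go, is whether adding the fluoro to compound 4 would give a lower number, as it does from compound 2 to compound 3. Also open, from the compounds shown here alone, is how the number would respond to a still longer chain, or to a chain ending in an amine or a carboxylic acid.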